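This account rests on a few compounds, and the source may have more. Where it says the series, first, only, none or still open, it means among the compounds named here.

Compound 1, `CS(=O)(=O)c1ccc(C(=O)NCCC(=O)N2CCc3ccccc3C2)cc1[N+](=O)[O-]`: > 60000 nM in an assay on isolated protein for inhibition of thyroid hormone receptor alpha (Homo sapiens), read by fluorescence polarization; a higher number here means a weaker inhibitor, a lower number a stronger inhibitor
Compound 2, `CC(C)N(C(=O)C1CCN(C(=O)c2ccc(S(C)(=O)=O)c([N+](=O)[O-])c2)CC1)C(C)C`: > 60000 nM
Compound 3, `Cc1ccc(N2CCN(C(=O)CCNC(=O)c3ccc(S(C)(=O)=O)c([N+](=O)[O-])c3)CC2)cc1`: > 60000 nM

All three measured compounds share the same core, and each was tested only in this assay. For compound 1 the value > 60000 nM is a limit of the assay rather than a measured number. For compound 2 the value > 60000 nM is likewise a limit. For compound 3 the value > 60000 nM is a limit as well. So compound 2 stands nowhere in particular among the values shown: it sits at the same limit as the other two, which is the picture summed up in the limit of > 60000 nM in this assay, at which 3 of the 3 values shown sit, and nothing separates the three compounds from one another.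

Compound 4, `CC1Cc2ccccc2N1C(=O)C1CCN(C(=O)c2ccc(S(C)(=O)=O)c([N+](=O)[O-])c2)CC1`, has not yet been tested. It differs from compound 2 in one place: 2-methyl-2,3-dihydro-1H-indol-1-yl in place of diisopropylamino on a carbonyl carbon. Among the compounds with values here, no step between two measured compounds is available, so the size of this change cannot be read from earlier data. With every value shown sitting at the limit, the expectation for this assay is that compound 4 also returns a limit rather than a number, with no step in either direction that can be told apart from the scatter. The estimated step of a number no higher from compound 2 to compound 4 (the limit leaves the size open) therefore means no meaningful change. Compound 4 is expected to give about 60000 nM, within the range 15000 nM to 300000 nM.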

Compound 4, half-maximal inhibitory concentration: > 60000 nM
Compound 4: only a limit was reported; the forecaster's own chance of this, stated with the estimate: 85%; the middle value sits exactly at the limit.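

Compound 4 gives > 60000 nM in this assay as a limit of the assay and not a number. Compound 2 sits at the same limit, so no step can be read between compound 2 and compound 4. The compounds shown leave open which change to the shared core, if any, would give a measurable value, as all rest at one limit: the limit of > 60000 nM in this assay, at which 4 of the 4 values shown sit.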